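Swapping the fluorophenyl ring on a piperazine amide

This account rests on a few compounds, and the source may have more. Where it says the series, first, only, none or still open, it means among the compounds named here.

Measured so far:
compound 1, `CC(C(=O)N1CCN(c2ccccc2F)CC1)N1C(=O)CCC1=O`, 50%
compound 2, `CCC(C(=O)N1CCN(c2ccc(F)cc2)CC1)N1C(=O)CCC1=O`, 25%

Of the compounds shown here, two have been tested in a functional assay on the whole organism (strain Swiss) with Mus musculus as the target, in the maximal electroshock model, with a stated time of 1 h, at a dose of 300 mg/kg by the intraperitoneal route; on this read-out lower numbers stand for a weaker effect and higher numbers for a stronger effect at the one dose given. Compound 1 gives 50%, while compound 2 gives 25%. Compound 2 thus stands lowest of the two numbers, and its nearest neighbour, compound 1, lies a margin above it that goes beyond the scatter of repeated measurements.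

Compound 3, `CCC(C(=O)N1CCN(c2ccccc2F)CC1)N1C(=O)CCC1=O`, has not yet been measured. It differs from compound 2 in a single place: 2-fluorophenyl in place of 4-fluorophenyl on an amine nitrogen in a ring.

No step between measured compounds is shown for this change, so any expectation rests on the fact that compound 1, which carries the same 2-fluorophenyl group and gives 50%, sits above compound 2. On that basis an upward step from compound 2 to compound 3 is expected, of the size a number 15 percentage points higher from compound 2 to compound 3 (beyond the scatter), which would reach beyond the scatter. In this assay compound 3 is accordingly estimated at 40%, with a range from 15% to 65%.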

Compound 3, a percentage reported as activity, at one dose (the size of the read-out at that dose, not a potency): 50%
Beside the measured number, compound 3's estimate is 10 percentage points below it; the measured number falls inside the stated range.
By their numbers in this assay, from the lowest: compound 2; then compounds 1 and 3 (each within the scatter of the next).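

In this assay, going by these compounds alone, 2-fluorophenyl in place of 4-fluorophenyl on an amine nitrogen in a ring gives a number 25 percentage points higher from compound 2 to compound 3 (beyond the scatter), the first direct reading of this change with the rest of the structure held fixed. Methyl in place of hydrogen on a saturated chain carbon, two bonds along the chain from an amide-type nitrogen in a ring and a carbonyl carbon, gives no change at the digits printed from compound 1 to compound 3 (within the scatter), so with 2-fluorophenyl in place, this step stays within the scatter. No supporting measurement bears on what lies behind either step.

On these data alone, whether that chain step would read alike with 4-fluorophenyl remains open, as does the outcome of a propyl group at the chain carbon. Also open, as far as these compounds go, is how a plain phenyl, a chlorophenyl or a methoxyphenyl on the ring nitrogen would compare with 2-fluorophenyl.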